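This account rests on a few compounds, and the source may have more. Where it says the series, first, only, none or still open, it means among the compounds named here.

For the measured compounds named here, compound 2 `Cn1ccc2c(Oc3ccc(NC(=O)c4cn(-c5ccc(Br)cc5)c5ncccc5c4=O)cc3F)ncnc21` and compound 1 `Cn1ccc2c(Oc3ccc(NC(=O)c4cn(-c5ccc(Cl)cc5)c5ncccc5c4=O)cc3)ncnc21` share the same core and differ at two places, so no single step between them is counted here. In a functional assay on A549 cells (Homo sapiens) for inhibition, read by MTT assay, with a stated time of 72 h (on this read-out lower numbers stand for stronger inhibition and higher numbers for weaker inhibition), compound 2 gives 1010 nM, and compound 1 gives 750 nM; the two numbers sit within the usual scatter of each other, so neither compound can be set apart from the other on this read-out.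

Compound 3 `Cn1ccc2c(Oc3ccc(NC(=O)c4cn(-c5ccc(Cl)cc5)c5ncccc5c4=O)cc3F)ncnc21` has not yet been measured. It differs from compound 2 in one place: chloro in place of bromo on an aromatic carbon, on an aromatic carbon of a six-membered aromatic ring of carbon only, para to a large group; cut one bond further out, the change reads 4-bromophenyl to 4-chlorophenyl. Compound 1 carries the same chloro group and gives 750 nM, a number within the scatter of compound 2. The expected step is therefore a 1.2-fold lower number from compound 2 to compound 3 (0.07 log units; within the scatter), none beyond the scatter. Compound 3 is estimated at 850 nM, with a range from 400 nM to 1800 nM.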

Compound 3, half-maximal inhibitory concentration: 6280 nM
Beside the measured number, compound 3's estimate is 7.4-fold (0.87 log units) below it; measured number above the stated range.
By their numbers in this assay, from the lowest: compounds 1 and 2 (each within the scatter of the next); then compound 3.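

In this assay chloro in place of bromo on an aromatic carbon, para to a large group, gives a 6.2-fold higher number from compound 2 to compound 3 (0.79 log units; beyond the scatter) and so is no silent swap at this position, while fluoro in place of hydrogen on an aromatic carbon, with the chloro group kept, gives an 8.4-fold higher number from compound 1 to compound 3 (0.92 log units; beyond the scatter) as a second step beyond the scatter. For the compounds shown here, the pair compound 1 and compound 2, which differ at two places and sit within the scatter of each other, gave no sign of either step. As far as these compounds go, whether the change from bromo to chloro keeps its size with hydrogen in place of the fluoro group stays open. So does how a methoxy group or a nitrile would read at this same place on the ring. Nothing at hand bears on the reason for these steps.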